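This account rests on a few compounds, and the source may have more. Where it says the series, first, only, none or still open, it means among the compounds named here.

Measured so far:
Compound 1 `CCCCc1nc2c(C)cccc2n1Cc1cc(Cl)c(O)c(Cl)c1`: 20 nM
Compound 2 `CCCc1nc2c(Cl)ccnc2n1Cc1ccc(-c2ccccc2C(=O)O)cc1`: 7.94 nM
Compound 3 `CCc1nc2c(C)ccnc2n1Cc1ccc(-c2ccccc2C(=O)O)cc1`: 1.26 nM

In a functional assay (aorta) with Oryctolagus cuniculus as the target (on this read-out higher numbers stand for weaker binding and lower numbers for tighter binding), compound 3 gives 1.26 nM, the lowest of the three numbers and so the tightest binding, with compound 1 and compound 2 both higher by more than the usual scatter. Compound 4 `CCSc1nc2c(C)ccnc2n1Cc1ccc(-c2ccccc2C(=O)O)cc1` has ethylsulfanyl in place of ethyl on an aromatic carbon of compound 3: ethylsulfanyl in place of ethyl on an aromatic carbon. For the measured compounds named here, no two measured compounds differ in only one place, so there is no direct precedent for this change. Since compound 3 already stands lowest at 1.26 nM, a small move toward a higher number in this assay is expected, perhaps not much beyond the scatter. The estimated change is a 2.0-fold higher number from compound 3 to compound 4 (0.30 log units; within the scatter). Compound 4 is estimated at 2.5 nM, with an expected range of 0.6 nM to 10 nM.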

Compound 4, dissociation constant: 5.01 nM
Estimate against measurement, compound 4: 2.0-fold (0.30 log units) below, within the range that was stated.
By their numbers in this assay, from the lowest: compound 3; then compounds 4 and 2 (each within the scatter of the next); then compound 1.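

For the compounds shown here, this is the first pair here that differs in only one place: ethylsulfanyl in place of ethyl on the aromatic carbon between two ring nitrogen atoms gives a 4.0-fold higher number from compound 3 to compound 4 (0.60 log units; beyond the scatter) in this assay. The position therefore responds to this change, though the step is modest and compound 4 still reads 5.01 nM. Nothing available explains the step.

From the compounds shown here alone, whether ethoxy or an ethylamino group on this carbon would read closer to compound 3 or compound 4 remains open. So does whether the step would repeat with other groups elsewhere on the shared core.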